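Swapping a Ring at the Edge of a Potent Series

The compounds below may be only part of what the source reports. "The series", "measured", "known", "first", "only" and "open" are said of these compounds alone.

Three compounds share one core and were measured in an assay on CHO cells for antagonist activity at transient receptor potential cation channel subfamily V member 1 (Homo sapiens), read by FLIPR; on this read-out lower numbers stand for stronger inhibition and higher numbers for weaker inhibition. Compound 1 `CC(C(=O)NCc1ccc(C(F)(F)F)cc1N1CCC(Cc2ccccc2)CC1)c1ccc(NS(C)(=O)=O)c(F)c1` gives 1.4 nM. Compound 2 `Cc1cccc(N2CCN(c3cc(C(F)(F)F)ccc3CNC(=O)C(C)c3ccc(NS(C)(=O)=O)c(F)c3)CC2)c1` gives 1.8 nM. Compound 3 `CC(C(=O)NCc1ccc(C(F)(F)F)cc1OC1CCCC1)c1ccc(NS(C)(=O)=O)c(F)c1` gives 0.6 nM, the lowest of the three numbers; its gaps to compound 1 and to compound 2 both lie beyond the scatter, so compound 3 stands as the most potent of the set.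

Compound 4 `COc1ccc(-c2cc(C(F)(F)F)ccc2CNC(=O)C(C)c2ccc(NS(C)(=O)=O)c(F)c2)cc1OC` is not yet measured. It differs from compound 3 in one place: 3,4-dimethoxyphenyl in place of cyclopentyloxy on an aromatic carbon. A larger aromatic group thus takes the seat of a small saturated ring.

For the measured compounds named here, no measured pair tells directly what this change does. Compound 1 and compound 2, which carry bulkier groups at the same place, sit somewhat higher than compound 3, so a modest weakening is expected. For compound 4 the expected step is a 2.5-fold higher number from compound 3 to compound 4 (0.40 log units; beyond the scatter). Compound 4 is therefore estimated at 1.5 nM, with a likely range from 0.5 nM to 5 nM.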

Compound 4, inhibition constant: 8.6 nM
The estimate for compound 4 lay 5.7-fold (0.76 log units) below the measured number; measured number above the stated range.
By their numbers in this assay, from the lowest: compound 3; then compounds 1 and 2 (each within the scatter of the next); then compound 4.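

In this assay, 3,4-dimethoxyphenyl in place of cyclopentyloxy gives a 14-fold higher number from compound 3 to compound 4 (1.16 log units; beyond the scatter), a large step showing that this aromatic carbon, ortho to a large group and meta to the trifluoromethyl group, does not treat all groups alike. The change replaces a five-membered non-aromatic ring with a six-membered aromatic ring carrying two methoxy groups, and this single step cannot separate the effects of those differences. Nothing measured here explains the loss in potency.

As far as these compounds go, what remains open is which part of the new group matters. A plain phenyl ring would test the aromatic ring without its methoxy groups, while a cyclohexyloxy group would test a larger saturated ring still joined through oxygen.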